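Cyano added to the 3-chlorophenyl group of compound 1

The source may hold more compounds than are shown below. What is called first, only, known or untested is meant among the compounds shown, and "the series" means these compounds.

For the measured compounds named here, compound 1 `Cc1cc(S(N)(=O)=O)ccc1NC(=O)COc1ccc(Cl)cc1NC(=O)c1cccc(Cl)c1` is one of three compounds measured in a functional assay on C8166 cells (Homo sapiens) for cytotoxicity, read by MTT assay (a lower number here means that less compound is tolerated, a higher number that more compound is tolerated), where compound 1 gives 59700 nM. It stands second highest of the three numbers: compound 3 `Cc1ccc(C(=O)Nc2cc(Cl)ccc2OCC(=O)Nc2ccc(S(N)(=O)=O)cc2C)c(C)c1` gives 47600 nM, and the step of a 1.3-fold lower number from compound 1 to compound 3 (0.10 log units; within the scatter) stays within the scatter; compound 2 `Cc1cc(S(N)(=O)=O)ccc1NC(=O)COc1ccc(Cl)cc1NC(=O)c1cccc(F)c1` gives 243000 nM, and the step of a 4.1-fold higher number from compound 1 to compound 2 (0.61 log units; beyond the scatter) lies beyond it, as does a 5.1-fold lower number from compound 2 to compound 3 (0.71 log units; beyond the scatter).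

Compound 4 `Cc1cc(S(N)(=O)=O)ccc1NC(=O)COc1ccc(Cl)cc1NC(=O)c1cc(Cl)cc(C#N)c1` is not yet measured. Its difference from compound 1: cyano in place of hydrogen on an aromatic carbon. The measured steps touch the same (3-chlorophenyl)carbonyl part of the shared core, but none adds a cyano group; the steps from compound 1 swap the 3-chlorophenyl for 3-fluorophenyl (a 4.1-fold higher number from compound 1 to compound 2 (0.61 log units; beyond the scatter), a modest step) or for 2,4-dimethylphenyl (a 1.3-fold lower number from compound 1 to compound 3 (0.10 log units; within the scatter), within the scatter). Neither speaks directly to a cyano group, so for compound 4 no step beyond the scatter in this assay is expected, and a 1.0-fold higher number from compound 1 to compound 4 (0.00 log units; within the scatter) is the expected step. Compound 4 is estimated at 60000 nM, with a range from 25000 nM to 150000 nM.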

Compound 4, half-maximal cytotoxic concentration: 131000 nM
Estimate against measurement, compound 4: 2.2-fold (0.34 log units) below; the measured number falls inside the stated range.
By their numbers in this assay, from the lowest: compounds 3 and 1 (each within the scatter of the next); then compounds 4 and 2 (each within the scatter of the next).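

In this assay, adding cyano to the 3-chlorophenyl group, meta to the chloro group, gives a step beyond the scatter, a 2.2-fold higher number from compound 1 to compound 4 (0.34 log units; beyond the scatter), so the number in this assay responds to substitution at this aromatic carbon. The 3-chloro-5-cyanophenyl group also separates from the 2,4-dimethylphenyl group, a 2.8-fold higher number from compound 3 to compound 4 (0.44 log units; beyond the scatter), but not from the 3-fluorophenyl group, a 1.9-fold lower number from compound 2 to compound 4 (0.27 log units; within the scatter), which places compound 4 with compound 2 at the more tolerated end of this set. Nothing available here accounts for these steps.

The compounds shown leave open whether the step from cyano depends on the chloro group on the same ring. They also leave open whether a carboxylic acid, an amine or a methoxy group on this carbon would move the number in the same direction.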